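Thiosemicarbazone series: aryl swap on the thioamide nitrogen

This account rests on a few compounds, and the source may have more. Where it says the series, first, only, none or still open, it means among the compounds named here.

compound 1 `COc1ccccc1NC(=S)N/N=C/c1ccc2ccccc2n1`: > 100000 nM
compound 2 `CN(C)C(=S)N/N=C/c1cc2cccnc2s1`: 13400 nM
compound 3 `NC(=S)N/N=C/c1cc2ccccc2s1`: 99200 nM

In a functional assay on HT-29 cells (Homo sapiens) for antiproliferative activity, read by sulforhodamine B assay, with a stated time of 72 h (on this read-out lower numbers stand for stronger inhibition and higher numbers for weaker inhibition), compound 1 returns only a limit, > 100000 nM, so its true value is not a number. This is the limit of > 100000 nM in this assay, at which 1 of the 3 values shown sits, and compound 1 is the one entry of the three that sits there. Compound 2 gives 13400 nM in this assay and compound 3 gives 99200 nM. For the measured compounds named here, no two measured compounds differ in a single place, so no step size can be read off the series.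

Compound 4 `S=C(N/N=C/c1ccc2ccccc2n1)Nc1ccc(Cl)cc1` differs from compound 1 by 4-chlorophenyl in place of 2-methoxyphenyl on an amide-type nitrogen. With compound 1 only bounded, the direction of this change cannot be anchored on a measured step. Compound 4 is expected at 60000 nM, within 15000 nM to 100000 nM. The estimated step of an at least 1.6-fold lower number from compound 1 to compound 4 (0.22 log units; that floor lies within the scatter) is taken as modest, with a real chance that only a limit is again reported.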

Compound 4, half-maximal inhibitory concentration: 97200 nM
Beside the measured number, compound 4's estimate is 1.6-fold (0.21 log units) below it; low and high end bracket the measured number.
By their numbers in this assay, from the lowest: compound 2; then compounds 4 and 3 (each within the scatter of the next). At a limit, above all of these: compound 1.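

In this assay, for the compounds shown here, 4-chlorophenyl in place of 2-methoxyphenyl on the amide-type nitrogen gives the first single-place step (an at least 1.0-fold lower number from compound 1 to compound 4 (0.01 log units; that floor lies within the scatter)). Compound 1 is only a limit, and the printed floor is not a true step size. With compound 4 at 97200 nM the core of compound 1 now carries a number rather than a limit.

On these data alone, it remains open whether a carboxylic acid or an amine on this aryl ring, or an unsubstituted phenyl, would move the number beyond the scatter. As far as these compounds go, the effect of moving the chlorine to another ring position also remains open.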